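The source may hold more compounds than are shown below. What is called first, only, known or untested is meant among the compounds shown, and "the series" means these compounds.

Working notes on the series. Compound 1 `Oc1ccc(O)c(-c2cc(-c3ccccc3)nn2-c2ccccc2)c1` and compound 2 `Oc1ccc(O)c(-c2cc(-c3ccc(Cl)cc3)nn2-c2ccccc2)c1` share one core and differ in a single place, a chloro in place of hydrogen on an aromatic carbon. In a functional assay on cells (Cancer cell lines, Homo sapiens) for cytotoxicity, read by sulforhodamine B assay, with a stated time of 48 h (on this read-out lower numbers stand for stronger inhibition of growth and higher numbers for weaker inhibition of growth), compound 1 gives 100000 nM and compound 2 gives 30700 nM; the step of a 3.3-fold lower number from compound 1 to compound 2 (0.51 log units; beyond the scatter) is modest yet beyond the scatter. Among the measured compounds shown here, compound 2 therefore stands at the lower of the two numbers so far, with compound 1 as its only neighbour.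

Compound 3 `O=C1C=CC(=O)C(c2cc(-c3ccc(Cl)cc3)nn2-c2ccccc2)=C1` is the next member and keeps the chloro of compound 2, differing from it in one place: a group of 8 heavy atoms (6 carbon, 2 oxygen; one six-membered non-aromatic ring of carbon only) in place of a group of 8 heavy atoms (6 carbon, 2 oxygen; one six-membered aromatic ring of carbon only), on an aromatic carbon. For the measured compounds named here, no measured step bears on this change: the only step on record, a 3.3-fold lower number from compound 1 to compound 2 (0.51 log units; beyond the scatter), concerns another place and another kind of exchange, so its size gives no guide here. The expectation for compound 3 in this assay rests on the value of compound 2 alone and carries a wide range. Compound 3 is estimated at 20000 nM, between 5000 nM and 80000 nM. This implies an expected step of a 1.5-fold lower number from compound 2 to compound 3 (0.19 log units; within the scatter), which is not claimed to exceed the scatter.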

Compound 3, concentration for total growth inhibition: 66400 nM
Compound 3: the middle estimate sits 3.3-fold (0.52 log units) below what was measured; measured number inside the range.
By their numbers in this assay, from the lowest: compound 2; then compounds 3 and 1 (each within the scatter of the next).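

Among the compounds shown here, the earlier pair spoke only to a chloro on the outer aromatic ring, whereas this step gives the first reading on the aromatic carbon next to the ring nitrogen. In this assay, putting the non-aromatic six-membered carbon ring in place of 2,5-dihydroxyphenyl gives a 2.2-fold higher number from compound 2 to compound 3 (0.34 log units; beyond the scatter), so this position responds to the exchange, though the step is modest and the number moves up rather than down. The exchange keeps the heavy-atom count and the hydrogen-bond acceptor count and takes the hydrogen-bond donors from 2 to 0, but nothing available links any of these differences to the step.

The compounds shown leave open how far the step depends on the two hydroxyl hydrogens, since a 2,5-dimethoxyphenyl group at this position would separate that feature from the ring change, and an amine or a carboxylic acid there would test the position more widely. They also leave open whether the same exchange gives a step of similar size with hydrogen in place of the chloro, or with a methoxy group on that outer ring.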